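This account rests on a few compounds, and the source may have more. Where it says the series, first, only, none or still open, it means among the compounds named here.

Compound 1, with the structure `CCc1nc2nc(C(F)(F)F)ccc2c(=O)n1Cc1cn(CC(=O)Nc2ccccc2)nn1`, and compound 2, with the structure `CCCCCCCCCCn1cc(Cn2c(CC)nc3nc(C(F)(F)F)ccc3c2=O)nn1`, share one core, while compound 3, with the structure `O=C(Cn1cc(COc2nc(-c3ccccc3)nc3nc(C(F)(F)F)ccc23)nn1)Nc1ccccc1`, and the as yet unmeasured compound 4, with the structure `CCCCCCCCCCn1cc(COc2nc(-c3ccccc3)nc3nc(C(F)(F)F)ccc23)nn1`, share another. How the two cores differ is not broken down here.

In a functional assay on HeLa cells (Homo sapiens) for antiproliferative activity, read by sulforhodamine B assay, with a stated time of 48 h (a higher number here means a weaker inhibitor of growth, a lower number a stronger inhibitor of growth), compound 1 gives 860 nM, and compound 2 gives 810 nM. The change between them is nonyl in place of phenylcarbamoyl on a saturated chain carbon bound to an aromatic nitrogen, and the step it made was a 1.1-fold lower number from compound 1 to compound 2 (0.03 log units; within the scatter). In this assay compound 3 gives 890 nM, which lies within the usual scatter of the numbers for both compound 1 and compound 2, so no order among the three can be drawn.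

The change from compound 3 to compound 4 is nonyl in place of phenylcarbamoyl on a saturated chain carbon bound to an aromatic nitrogen. It is the same change as from compound 1 to compound 2, made at the same kind of place, and among these compounds it occurs twice in all. Since that earlier step was within the scatter, a similarly small step is expected here, namely a 1.1-fold lower number from compound 3 to compound 4 (0.04 log units; within the scatter), the expectation resting on the step of a 1.1-fold lower number from compound 1 to compound 2 (0.03 log units; within the scatter) and on compound 3 giving 890 nM. Compound 4 is therefore estimated at 820 nM in this assay. For compound 4 the expected range runs from 400 nM to 1700 nM.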

Compound 4, concentration for 50% growth inhibition: 1040 nM
Compound 4: the middle estimate sits 1.3-fold (0.10 log units) below what was measured; measured number inside the range.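

In this assay, nonyl in place of phenylcarbamoyl on the core of compound 3 gives a 1.2-fold higher number from compound 3 to compound 4 (0.07 log units; within the scatter), and the same change on the core of compound 1 gives a step that agrees with it: the same change on two cores in this assay, a 1.1-fold lower number (0.03 log units; within the scatter) from compound 1 to compound 2 and a 1.2-fold higher number (0.07 log units; within the scatter) from compound 3 to compound 4, 1.2-fold (0.09 log units) apart, within the scatter of two such steps. On these two cores, then, the change carries over in the limited sense that neither step leaves the scatter, so the result on one core was a fair guide to the result on the other. It does not show that the two cores respond alike to a change with a step large enough to read, since neither step here has a direction that can be trusted, and two pairs set no rule for any further core or for any other assay.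

The compounds shown leave open how a shorter chain, a longer chain, an amine or a carboxylic acid at the end of the triazole-free part of this substituent, on a saturated chain carbon bound to an aromatic nitrogen, would read in this assay. They also leave open what the difference between the two cores contributes, as no pair shown differs in that part alone.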